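This account rests on a few compounds, and the source may have more. Where it says the series, first, only, none or still open, it means among the compounds named here.

- Compound 1 `COC(=O)c1cc(C2=C(c3cc(OC)c(OC)c(OC)c3)C(=O)CC2O[SiH2]C(C)(C)C)ccc1OC`: > 100 ug/mL
- Compound 2 `COc1cc(C2=C(c3ccc(SC)cc3)CC(O[SiH2]C(C)(C)C)C2=O)cc(OC)c1OC`: < 1 ug/mL
- Compound 3 `COc1cc(C2=C(c3ccc(OCC(=O)O)cc3)C(O)CC2=O)cc(OC)c1OC`: "not determined" (no result reported)

These entries all come from an ADME assay on HT-29 cells (Homo sapiens) for cytotoxicity, read by MTT assay, with a stated time of 72 h; on this read-out higher numbers stand for weaker inhibition and lower numbers for stronger inhibition. The value for compound 1 is > 100 ug/mL, which is a limit of the assay and not a number. Compound 1 therefore stands at the limit of > 100 ug/mL in this assay, at which 1 of the 3 values shown sits, on the weak side of the values shown. The value for compound 2 is < 1 ug/mL, which is also a limit. Compound 2 stands at the limit of < 1 ug/mL in this assay, at which 1 of the 3 values shown sits. Compound 3 offers no comparison, as its entry reads "not determined" (no result reported).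

Compound 4 `COc1cc(C2=C(c3ccccc3)C(O[SiH2]C(C)(C)C)CC2=O)cc(OC)c1OC` has yet to be measured. Moving to it from compound 1 puts phenyl in place of 4-methoxy-3-(methoxycarbonyl)phenyl on a double-bonded ring carbon. Going by the values given here, no measured pair of compounds differing in one place is available, so this estimate is uncertain. Compound 2, with its limit of < 1 ug/mL, shows that strong inhibition can occur in this set. A clear step towards stronger inhibition in this assay is therefore expected, rather than none beyond the scatter. The expected change is an at least 5.0-fold lower number from compound 1 to compound 4 (0.69 log units; beyond the scatter). For compound 4, the estimated value is 20 ug/mL, with an expected range of 3 ug/mL to 100 ug/mL.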

Compound 4, half-maximal inhibitory concentration: > 100 ug/mL
Compound 4 gave a limit, no number; the forecaster's own chance of this, stated with the estimate: 30%; middle value at least 5.0-fold (0.69 log units) away from the limit.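

In this assay compound 4 gives > 100 ug/mL, a limit of the assay and not a number. Going by these compounds alone, compound 1 also gives a limit, > 100 ug/mL, so no step to compound 4 can be read. The compounds shown leave open whether phenyl in place of 4-methoxy-3-(methoxycarbonyl)phenyl on a double-bonded ring carbon changes inhibition at all.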